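Fluoro in place of hydrogen: outlook for compound 4

This account rests on a few compounds, and the source may have more. Where it says the series, first, only, none or still open, it means among the compounds named here.

The series shares the core of compound 1 `C=C(C)C(=O)Nc1cccc(-c2nc3ccccc3s2)c1`; compound 2 `O=C(Nc1cccc(-c2nc3ccccc3s2)c1)c1cnccc1Cl` and compound 3 `O=C(Nc1cccc(-c2nc3ccccc3s2)c1)c1ccncc1Cl` carry a different group on the carbonyl carbon. In an ADME assay on HEK293 cells (Homo sapiens) for inhibition, with a stated time of 72 h (a higher number here means that more compound is needed for the effect, a lower number that less compound is needed), compound 1 returns only a limit, > 25000 nM. In this assay compound 2 likewise returns only a limit, > 25000 nM. Compound 3 also returns only a limit, > 25000 nM. The step that the two limits leave unreadable from compound 1 to compound 2, the step that the two limits leave unreadable from compound 1 to compound 3 and the step that the two limits leave unreadable from compound 2 to compound 3 therefore cannot be sized. Compound 2 stands where every value of the series stands, at the limit of > 25000 nM in this assay, at which 3 of the 3 values shown sit.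

Compound 4 `O=C(Nc1cc(-c2nc3ccccc3s2)ccc1F)c1cnccc1Cl` differs from compound 2 by fluoro in place of hydrogen on an aromatic carbon. Among the measured compounds shown here, no measured step touches this position: the three steps on record all change the group on the carbonyl carbon, and none of them is readable. The measured compounds give no direction for this assay, so the most probable outcome for compound 4 is another limit. The estimate for compound 4 in this assay is 30000 nM, with an expected range from 8000 nM to 100000 nM. The expected step is a step that the limit leaves unreadable from compound 2 to compound 4, which amounts to no readable change.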

Compound 4, half-maximal effective concentration: > 25000 nM
Compound 4 ended at the assay's limit; the forecaster's own chance of this, stated with the estimate: 80%; the middle value lies beyond the limit too.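

No new step can be read: in this assay compound 4 gives only a limit, > 25000 nM, so its fluoro in place of hydrogen cannot be sized against compound 2. It remains open whether any change to these compounds moves the half-maximal effective concentration at all, and in which direction, with every reading so far a limit: the limit of > 25000 nM in this assay, at which 4 of the 4 values shown sit.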